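A few compounds are considered here, and "the series" means these few. Any claim that something is new, unique, unknown or untested is made for them only; others in the source may bear on it.

Three compounds share one core and differ in two side groups. Compound 1 `CCN(CC)CCCS(=O)(=O)c1ccc2nc(NC(=O)NC(=O)c3cc(-n4cccn4)ccc3Cl)sc2c1` gives 2.1 in a physicochemical assay for lipophilicity; on this read-out lower numbers stand for lower lipophilicity and higher numbers for higher lipophilicity. Compound 2 `CN1CCC(S(=O)(=O)c2ccc3nc(NC(=O)NC(=O)c4cc(N5CCCC5)ccc4Cl)sc3c2)CC1` gives 3.1 in this assay. Compound 3 `Cc1ccnn1-c1ccc(Cl)c(C(=O)NC(=O)Nc2nc3ccc(S(=O)(=O)C4CCN(C)CC4)cc3s2)c1` gives 2.6, the second highest of the three numbers, with compound 1 sitting lower and compound 2 sitting higher, both beyond the scatter. Among the measured compounds shown here, the one measured step, a number 0.50 log units lower from compound 2 to compound 3 (beyond the scatter), concerns a different exchange. Compound 4 `CN1CCC(S(=O)(=O)c2ccc3nc(NC(=O)NC(=O)c4cc(-n5cccn5)ccc4Cl)sc3c2)CC1` differs from compound 3 by hydrogen in place of methyl on an aromatic carbon. For the measured compounds named here, no measured step matches this change directly; compound 1, which also carries 1H-pyrazol-1-yl but another amine, lies lower than compound 3. Losing one carbon is expected to lower this assay slightly, a number 0.40 log units lower from compound 3 to compound 4 (beyond the scatter). Compound 4 is expected to give 2.2, within 1.7 to 2.7.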

Compound 4, distribution coefficient: 2.5
Estimate against measurement, compound 4: 0.30 log units below; the range from low to high includes it.
By their numbers in this assay, from the lowest: compound 1; then compounds 4 and 3 (each within the scatter of the next); then compound 2.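

In this assay, hydrogen in place of methyl on the five-membered aromatic ring gives a number 0.10 log units lower from compound 3 to compound 4 (within the scatter) and so leaves no readable difference at this position. Compound 4 also allows single-change readings of the other two side groups: a number 0.60 log units lower from compound 2 to compound 4 (beyond the scatter) for 1H-pyrazol-1-yl in place of pyrrolidin-1-yl, and a number 0.40 log units higher from compound 1 to compound 4 (beyond the scatter) for 1-methylpiperidin-4-yl in place of 3-(diethylamino)propyl. No supporting measurement accounts for any of these steps. As far as these compounds go, it remains open whether ethyl or trifluoromethyl on that ring carbon would also stay within the scatter. From the compounds shown here alone, how a carboxylic acid on the sulfonyl side chain would read is also open.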